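The source may report more compounds than this note shows. Statements on the series, on what has been measured and on what is new or still open speak of the compounds shown alone.

In an ADME assay on L6 cells (Rattus norvegicus) for cytotoxicity, read by fluorescence and resazurin assay, with a stated time of 72 h (on this read-out lower numbers stand for higher toxicity in this test and higher numbers for lower toxicity in this test), compound 1 `CC(C)(C)c1ccc(-c2c[nH]cc2C(c2ccc(Cl)cc2Cl)n2ccnc2)cc1` gives 22900 nM, compound 2 `N#Cc1ccc(-c2c[nH]cc2C(c2ccc(Cl)cc2Cl)n2ccnc2)cc1` gives 15000 nM and compound 3 `FC(F)(F)c1ccc(-c2c[nH]cc2C(c2ccc(Cl)cc2Cl)n2ccnc2)cc1` gives 9400 nM. Compound 2 stands within the scatter of both other compounds. The measured steps are a 1.5-fold lower number from compound 1 to compound 2 (0.18 log units; within the scatter) and a 1.6-fold lower number from compound 2 to compound 3 (0.20 log units; within the scatter), and only a 2.4-fold lower number from compound 1 to compound 3 (0.39 log units; beyond the scatter) goes beyond the scatter. Compound 4 `Clc1ccc(-c2c[nH]cc2C(c2ccc(Cl)cc2Cl)n2ccnc2)c(Cl)c1` brings a larger exchange: 2,4-dichlorophenyl in place of 4-cyanophenyl on an aromatic carbon. For the measured compounds named here, no measured step replaces the whole 4-cyanophenyl, so the evidence is indirect. All three steps are small, and the expectation is therefore a small change in this assay, probably downward. The expected step is a 1.7-fold lower number from compound 2 to compound 4 (0.22 log units; within the scatter). Compound 4 is estimated at 9000 nM, with an expected range from 4000 nM to 20000 nM.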

Compound 4, half-maximal cytotoxic concentration: 9860 nM
Compound 4: the middle estimate sits 1.1-fold (0.04 log units) below what was measured; the range from low to high includes it.
By their numbers in this assay, from the lowest: compounds 3, 4, 2 and 1 (each within the scatter of the next, the first and the last beyond it).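

Replacing the whole 4-cyanophenyl with 2,4-dichlorophenyl in this assay gives a 1.5-fold lower number from compound 2 to compound 4 (0.18 log units; within the scatter) and no step beyond the scatter. Unlike the earlier exchanges, this one removes the nitrile and places two chlorine atoms on the aromatic ring at this position, next to the ring atom that bears a large group. No measurement here accounts for the result. The compounds shown leave open how 4-chlorophenyl, with a single chlorine, would compare with 2,4-dichlorophenyl. They also leave open how an amine or a carboxylic acid on this aromatic ring would read.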